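Sulfur-linked iodobenzyl in place of benzyloxy at the purine

A few compounds are considered here, and "the series" means these few. Any claim that something is new, unique, unknown or untested is made for them only; others in the source may bear on it.

The study concerns three measured compounds and one yet to be tested, all judged in an assay on isolated protein for binding affinity to Equilibrative nucleoside transporter 1 (Homo sapiens); on this read-out higher numbers stand for weaker inhibition and lower numbers for stronger inhibition. Compound 1 `O=[N+]([O-])c1ccc2c(c1)CN(c1ncnc3c1ncn3[C@@H]1O[C@H](CO)[C@@H](O)[C@H]1O)CC2` gives 5.5 nM in this assay. Compound 2 `OC[C@H]1O[C@@H](n2cnc3c(OCc4ccccc4)ncnc32)[C@H](O)[C@@H]1O` gives 2090 nM, the second highest of the three numbers; compound 3 `OC[C@H]1O[C@@H](n2cc(I)c3c(Cl)ncnc32)[C@H](O)[C@@H]1O` gives 77600 nM, the higher of the two, while compound 1 lies far below compound 2, both gaps beyond the usual scatter.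

Compound 4 `OC[C@H]1O[C@@H](n2cnc3c(CSc4cccc(I)c4)ncnc32)[C@H](O)[C@@H]1O` has not yet been measured. It differs from compound 2 in one place: a group of 9 heavy atoms (7 carbon, 1 sulfur, 1 iodine; one six-membered aromatic ring of carbon only) in place of a group of 8 heavy atoms (7 carbon, 1 oxygen; one six-membered aromatic ring of carbon only), on an aromatic carbon. The new group sits on an aromatic carbon of a six-membered aromatic ring with two nitrogen atoms, part of a fused system of two rings, next to the ring nitrogen.

For the measured compounds named here, no step between measured compounds guides this change directly. The account nevertheless expects compound 4 to show stronger inhibition than compound 2, with an estimated step of a 21-fold lower number from compound 2 to compound 4 (1.32 log units; beyond the scatter) in this assay, well beyond the scatter. The estimate for compound 4 is 100 nM, within a range from 20 nM to 600 nM.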

Compound 4, half-maximal inhibitory concentration: 245 nM
Estimate against measurement, compound 4: 2.5-fold (0.39 log units) below, within the range that was stated.
By their numbers in this assay, from the lowest: compound 1; then compound 4; then compound 2; then compound 3.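

For the compounds shown here, replacing benzyloxy on this aromatic carbon gives an 8.5-fold lower number from compound 2 to compound 4 (0.93 log units; beyond the scatter) in this assay, the first step between measured compounds that differ in one place. It shows that this position is not tied to benzyloxy: inhibition grows when oxygen leaves and sulfur and iodine enter, while the six-membered aromatic ring of carbon only stays. Nothing available explains this gain, so the step stands as an observation only.

The step bundles these changes, so the compounds shown leave open how much of it belongs to the sulfur and how much to the iodine; a benzyloxy group carrying iodine, or the sulfur-linked group with hydrogen in place of iodine, would separate them. They also leave open whether a different halogen, such as bromine, or an amine on that benzene ring would hold the gain.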